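The source may report more compounds than this note shows. Statements on the series, on what has been measured and on what is new or still open speak of the compounds shown alone.

In a functional assay on HL-60 cells (Homo sapiens) for antiproliferative activity, read by MTT assay, with a stated time of 72 h (a higher number here means a weaker inhibitor, a lower number a stronger inhibitor), compound 1 (`Cc1ccc(S(=O)(=O)NC(=N)N2CCN(c3cc4c(cc3F)c(=O)c(C(=O)O)cn4C3CC3)CC2)cc1`) gives 43 nM and compound 2 (`N=C(NS(=O)(=O)c1ccccc1Cl)N1CCN(c2cc3c(cc2F)c(=O)c(C(=O)O)cn3C2CC2)CC1`) gives 43 nM so compound 2 stands level with compound 1. Compound 3 (`N=C(NS(=O)(=O)c1ccccc1C(F)(F)F)N1CCN(c2cc3c(cc2F)c(=O)c(C(=O)O)cn3C2CC2)CC1`) is not yet measured. It carries trifluoromethyl in place of chloro on an aromatic carbon, ortho to a large group (trifluoromethyl in place of chloro on an aromatic carbon). For the measured compounds named here, only one measured step bears on this change (no change at the digits printed from compound 1 to compound 2 (within the scatter)) and it stayed within the scatter. No step beyond the scatter is therefore expected in this assay and no direction can be assigned. The expected step is small (a 1.0-fold higher number from compound 2 to compound 3 (0.02 log units; within the scatter)). Compound 3 is estimated at 45 nM (range 18 nM to 110 nM).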

Compound 3, half-maximal inhibitory concentration: 43 nM
Estimate against measurement, compound 3: 1.0-fold (0.02 log units) above, within the range that was stated.
By their numbers in this assay, from the lowest: compounds 1, 2 and 3 (each within the scatter of the next).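

In this assay the larger trifluoromethyl, with four heavy atoms against one for chloro, gives no change at the digits printed from compound 2 to compound 3 (within the scatter) on this aromatic carbon, so the enlarged group brings no step beyond the scatter. Against the 4-methylphenyl group on the sulfonyl sulfur, 2-(trifluoromethyl)phenyl gives no change at the digits printed from compound 1 to compound 3 (within the scatter) and also stays within the scatter. Nothing at hand offers an explanation for this flat result. Going by these compounds, whether an amine or a carboxylic acid on this aromatic carbon would stay level remains open. So does the effect of a longer alkyl chain in place of the phenyl group on the sulfonyl sulfur.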